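Changing a five-membered amine ring to six members

The source may hold more compounds than are shown below. What is called first, only, known or untested is meant among the compounds shown, and "the series" means these compounds.

- compound 1 `C=CS(=O)(=O)N1CCN(c2ncnc3sc(-c4ccc(C#N)cc4)cc23)CC1` gives 9170 nM
- compound 2 `C=CS(=O)(=O)N1CCN(c2nc(OC[C@H]3CCCN3C)nc3sc(-c4ccc(C#N)cc4)cc23)CC1` gives 2290 nM

Both compounds were tested in a functional assay on MDA-MB-436 cells (Homo sapiens) for antiproliferative activity, read by MTT assay, with a stated time of 48 h; on this read-out lower numbers stand for stronger inhibition and higher numbers for weaker inhibition. Of the two, compound 2 (2290 nM) has the lower number and so the stronger inhibition. Compound 3 `C=CS(=O)(=O)N1CCN(c2nc(OCC3CCCCN3C)nc3sc(-c4ccc(C#N)cc4)cc23)CC1` differs from compound 2 in one place (1-methylpiperidin-2-yl in place of 1-methylpyrrolidin-2-yl on a saturated chain carbon bound to an oxygen on an aromatic ring), with 1-methylpiperidin-2-yl in place of 1-methylpyrrolidin-2-yl on a saturated chain carbon bound to an oxygen on an aromatic ring. For the measured compounds named here, only one measured step bears on this (a 4.0-fold lower number from compound 1 to compound 2 (0.60 log units; beyond the scatter)). It came with (1-methylpyrrolidin-2-yl)methoxy in place of hydrogen on an aromatic carbon, so it concerns adding the whole group. Going by the values given here, no measurement yet tests ring size. Compound 3 still carries a closely related group, so in this assay no step beyond the scatter is expected, in either direction. The expected step is small (a 1.1-fold higher number from compound 2 to compound 3 (0.04 log units; within the scatter)). For compound 3 the estimated value is 2500 nM, with an expected range from 1100 nM to 5500 nM.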

Compound 3, half-maximal inhibitory concentration: 4080 nM
For compound 3 the middle estimate is 1.6-fold (0.21 log units) below the measured one, and the stated range covers the measured number.
By their numbers in this assay, from the lowest: compounds 2 and 3 (each within the scatter of the next); then compound 1.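

In this assay, enlarging the ring gives a 1.8-fold higher number from compound 2 to compound 3 (0.25 log units; within the scatter), so this read-out does not separate the five-membered from the six-membered ring at this place. The six-membered version also keeps a measurable difference from hydrogen: the change from hydrogen to (1-methylpiperidin-2-yl)methoxy on an aromatic carbon gives a 2.2-fold lower number from compound 1 to compound 3 (0.35 log units; beyond the scatter), so two related ring amines now show a lower number than hydrogen. No supporting data are available to explain these results.

As far as these compounds go, it remains open whether a ring is required at all, or whether an open-chain group such as dimethylaminoethoxy, or a plain methoxy without any amine, would give a similar number. The ring-size comparison is also not entirely clean, as the 1-methylpyrrolidin-2-yl group has a defined stereocentre while the 1-methylpiperidin-2-yl group has none.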